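From 2-methylphenyl to 4-chlorophenyl on a shared core

The source may hold more compounds than are shown below. What is called first, only, known or untested is meant among the compounds shown, and "the series" means these compounds.

Values measured so far in a functional assay on HeLa cells (Homo sapiens) for cytotoxicity, read by ELISA, with a stated time of 4 days; on this read-out lower numbers stand for stronger inhibition and higher numbers for weaker inhibition
- Compound 1 `Cc1ccsc1-c1cc(-c2ccoc2)cc(-c2ccco2)n1` gives 30500 nM
- Compound 2 `Clc1ccc(-c2cc(-c3ccco3)cc(-c3ccc(Cl)s3)n2)cc1` gives 17000 nM
- Compound 3 `Cc1ccccc1-c1cc(-c2ccoc2)cc(-c2ccc(Cl)s2)n1` gives 19000 nM

Compound 3 at 19000 nM cannot be told apart from the other two compounds. Its gaps to compound 1 and to compound 2 both lie within the usual scatter of repeated measurements, and so does the gap between those two.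

Still unmeasured is compound 4 `Clc1ccc(-c2cc(-c3ccoc3)cc(-c3ccc(Cl)s3)n2)cc1` which has 4-chlorophenyl in place of 2-methylphenyl on an aromatic carbon and otherwise matches compound 3. Within the data shown here, no two measured compounds differ in only one place, so the data give no direct size for this swap. In this assay compound 2, which also carries 4-chlorophenyl, gives 17000 nM and stays within the scatter of compound 3. No change beyond the scatter is therefore expected, and the estimated move is a 1.1-fold lower number from compound 3 to compound 4 (0.05 log units; within the scatter) in size. For compound 4 the estimated value is 17000 nM and the expected range runs from 8000 nM to 35000 nM in this measurement.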

Compound 4, half-maximal inhibitory concentration: 16500 nM
For compound 4 the middle estimate is 1.0-fold (0.01 log units) above the measured one; the measured number falls inside the stated range.
By their numbers in this assay, from the lowest: compounds 4, 2, 3 and 1 (each within the scatter of the next).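

In this assay the exchange on the aromatic carbon next to the ring nitrogen now has a direct size: 4-chlorophenyl in place of 2-methylphenyl gives a 1.2-fold lower number from compound 3 to compound 4 (0.06 log units; within the scatter) and so makes no change that can be told from the scatter. The furan also gets its first direct test, as furan-3-yl in place of furan-2-yl gives a 1.0-fold lower number from compound 2 to compound 4 (0.01 log units; within the scatter) and likewise stays within the scatter. Nothing measured here explains either result.

Going by these compounds, both exchanges replace one aromatic ring with another, so it remains open whether an amine or a carboxylic acid next to the ring nitrogen would move the number beyond the scatter. On these data alone, it is equally open whether a longer chain in place of the furan ring would do so.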